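A few compounds are considered here, and "the series" means these few. Any claim that something is new, unique, unknown or untested is made for them only; others in the source may bear on it.

Compound 1 `COCOc1ccc(/C=C/C(=O)N2CCN(Cc3ccc(Cl)c(Cl)c3)CC2)cc1OCOC` gives 19300 nM in a functional assay on K562 cells (Homo sapiens) for cytotoxicity, read by MTT assay, with a stated time of 72 h; on this read-out lower numbers stand for stronger inhibition and higher numbers for weaker inhibition. Compound 2 `CCOc1ccc(COc2c(OC)cc(/C=C/C(=O)N3CCN(Cc4ccc(Cl)c(Cl)c4)CC3)cc2OC)cc1` gives 1700 nM. Compound 3 `O=C(COC(=O)/C=C/c1ccc(O)c(O)c1)NN1CCOCC1` gives 56800 nM.

Compound 3 stands highest of the three numbers in this assay: compound 1 lies lower by a gap beyond the scatter, and compound 2 lies lower still, also beyond the scatter. Compound 4 `O=C(COC(=O)/C=C/c1ccc(O)c(O)c1)Nc1ccc(Cl)cc1` differs from compound 3 by 4-chlorophenyl in place of morpholin-4-yl on an amide-type nitrogen. For the measured compounds named here, no pair of measured compounds shows this change, so nothing measured tells its size or direction. The writer expects a modest step toward a lower number, a 2.3-fold lower number from compound 3 to compound 4 (0.36 log units; beyond the scatter), though a step within the scatter remains possible. For compound 4 the writer estimates 25000 nM, with a range from 8000 nM to 80000 nM.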

Compound 4, half-maximal inhibitory concentration: 99400 nM
The estimate for compound 4 lay 4.0-fold (0.60 log units) below the measured number, outside the stated range (above it).
By their numbers in this assay, from the lowest: compound 2; then compound 1; then compounds 3 and 4 (each within the scatter of the next).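

Placing 4-chlorophenyl in place of morpholin-4-yl on an amide-type nitrogen gives a 1.8-fold higher number from compound 3 to compound 4 (0.24 log units; within the scatter) in this assay and so provides the first measured reading of this change. Here, the six-membered aromatic ring of carbon only and the six-membered non-aromatic ring with 2 hetero atoms are not told apart. No available evidence bears on this result. The compounds shown leave open how a dimethylamino group or a benzyl group would read on this nitrogen.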